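One More Methoxy Group: Expecting No Change

The source may report more compounds than this note shows. Statements on the series, on what has been measured and on what is new or still open speak of the compounds shown alone.

Three measured compounds share one core and differ only in the aromatic ring at one end of the chain. In a functional assay on the whole organism (strain Kunming) with Mus musculus as the target, with a stated time of 0.5 h, at a dose of 300 mg/kg by the intraperitoneal route (on this read-out lower numbers stand for a stronger effect and higher numbers for a weaker effect at the one dose given), compound 1 `COc1ccccc1/C=C/C(=O)OC/C=C/c1cc(OC)c(OC)cc1OC` gives 100%. In this assay compound 2 `COc1cc(OC)c(OC)cc1/C=C/COC(=O)/C=C/c1ccc(OC)c(OC)c1` gives 100%, and compound 3 `COc1cc(OC)c(OC)cc1/C=C/COC(=O)/C=C/c1cccc(Br)c1` gives 100%. The three ring swaps show no change at the digits printed from compound 1 to compound 2 (within the scatter), no change at the digits printed from compound 1 to compound 3 (within the scatter) and no change at the digits printed from compound 2 to compound 3 (within the scatter), so compound 2 stands level with compound 1 and compound 3 on the numbers shown.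

Compound 4 `COc1cc(OC)c(OC)cc1/C=C/COC(=O)/C=C/c1ccc(OC)c(OC)c1OC` differs from compound 2 by a single change: methoxy in place of hydrogen on an aromatic carbon. For the measured compounds named here, the steps that bear on this are the three ring swaps already measured, each of which left the read-out unchanged within the scatter even when whole substituent patterns or a bromine-for-methoxy exchange were involved. A smaller change, one added methoxy group, is therefore expected to behave the same way, and the step expected is no change at the digits printed from compound 2 to compound 4 (within the scatter), that is, none beyond the scatter. For compound 4 the expected value is 100%, with an expected range from 88% to 100%.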

Compound 4, a percentage reported as activity, at one dose (the size of the read-out at that dose, not a potency): 100%
Estimate against measurement, compound 4: no gap at the digits printed, and the stated range covers the measured number.
By their numbers in this assay, from the lowest: compounds 1, 2, 3 and 4 (each within the scatter of the next).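

In this assay, methoxy in place of hydrogen gives no change at the digits printed from compound 2 to compound 4 (within the scatter). The earlier steps shown here exchanged one substituent pattern on the ring for another, whereas this step adds a single group on an aromatic carbon, ortho to a large group and ortho to a methoxy group, and the read-out stays level. No measurement shown here offers an explanation for this result.

As far as these compounds go, whether a different group at this same place, such as an amine or a carboxylic acid, would move the read-out remains open. Also open is whether changes on the ring at the other end of the chain, which is the same in all four compounds, would separate them in this assay, given that the compounds shown all print the same value.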